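The source may hold more compounds than are shown below. What is called first, only, known or untested is meant among the compounds shown, and "the series" means these compounds.

Compound 1, `O=C1c2ccc(OCc3cccc(-c4ccccc4)c3)cc2CN1C1CCCC1`, was tested in an assay on HEK293 cells for positive allosteric modulation of metabotropic glutamate receptor 2 (Rattus norvegicus), read by thallium flux; a lower number here means that less compound is needed, a higher number that more compound is needed for the effect. Compound 1 gives only a limit there, > 5000 nM, so no exact number is known for it. Compound 1 thus stands at the limit of > 5000 nM in this assay, at which 1 of the 2 values shown sits. Among the compounds with values here, compound 2, `CN(C)C(=O)c1cc(-c2cccc(COc3ccc4c(=O)n(C5CCCC5)sc4c3)c2)ccc1Cl`, differs from compound 1 in more than one place, so no single step connects them; in this assay compound 2 gives 980 nM, an exact number rather than a limit. Compound 3, `COc1ccc(-c2cccc(COc3ccc4c(c3)CN(C3CCCC3)C4=O)c2)cc1C(=O)O`, has not yet been measured. It differs from compound 1 by 3-carboxy-4-methoxyphenyl in place of phenyl on an aromatic carbon. Within the data shown here, no measured pair shows this single change, so the size of the step is open. The step expected in this assay is an at least 2.0-fold lower number from compound 1 to compound 3 (0.30 log units; that floor lies within the scatter), a move below the limit, with wide uncertainty as to whether it exceeds the usual scatter. For compound 3 the estimated value in this assay is 2500 nM, within a range from 600 nM to 10000 nM.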

Compound 3, half-maximal effective concentration: 170 nM
Estimate against measurement, compound 3: 15-fold (1.17 log units) above; measured number outside the range, below it.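

In this assay, this position on compound 1 proves open to change: exchanging the plain phenyl for the larger 3-carboxy-4-methoxyphenyl gives an at least 29-fold lower number from compound 1 to compound 3 (1.46 log units; beyond the scatter), a step clearly larger than the usual variation between repeats. The earlier compounds shown here could not show this, as compound 1 and compound 2 differ in more than one place and no single change could be read from them. On these data alone, the true size of the step remains unknown, because compound 1 gives only a limit rather than an exact number: the limit of > 5000 nM in this assay, at which 1 of the 3 values shown sits.

The carboxylic acid and the methoxy group enter together, and the compounds shown do not separate them. A phenyl carrying only one of the two, or a primary amide in place of the acid, would show which part goes with the lower number.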